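A Methyl Added Twice: Estimating Compound 4

The source may hold more compounds than are shown below. What is called first, only, known or untested is meant among the compounds shown, and "the series" means these compounds.

Of the compounds shown here, three have so far been measured in an assay on HEK293 cells for positive allosteric modulation of metabotropic glutamate receptor 2 (Rattus norvegicus), read by thallium flux, with a stated time of 2.5 min; on this read-out higher numbers stand for an effect only at larger amounts of compound and lower numbers for an effect already at smaller amounts. Compound 1 `Cc1c(OCCCCOc2ccc(C(=O)C(C)C)c(O)c2C)cccc1C(=O)O` gives 149 nM, compound 2 `CCC(=O)c1ccc(OCCCCOc2cccc(C(=O)O)c2C)c(C)c1O` gives 62 nM, and compound 3 `CCC(=O)c1ccc(OCCCCOc2ccc(F)c(C(=O)O)c2)c(C)c1O` gives 124 nM. Compound 4 `Cc1c(OCCCCOc2ccc(F)c(C(=O)O)c2)ccc(C(=O)C(C)C)c1O` has not yet been measured. Compound 4 differs from compound 3 by methyl in place of hydrogen on a saturated chain carbon bound to a carbonyl carbon and a saturated chain carbon. The same change, (methyl in place of hydrogen on a saturated chain carbon bound to a carbonyl carbon and a saturated chain carbon), has already been made once among the measured compounds and gave a 2.4-fold higher number from compound 2 to compound 1 (0.38 log units; beyond the scatter). The difference between the cores of compound 2 and compound 3 is not broken down here; their two values lie within the usual scatter of each other. For compound 4 a step of a 2.3-fold higher number from compound 3 to compound 4 (0.35 log units; beyond the scatter) is expected, because the same change gave a 2.4-fold higher number from compound 2 to compound 1 (0.38 log units; beyond the scatter). Compound 4 is therefore estimated at 280 nM, with a likely range from 120 nM to 650 nM.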

Compound 4, half-maximal effective concentration: 171 nM
Beside the measured number, compound 4's estimate is 1.6-fold (0.21 log units) above it; the measured number falls inside the stated range.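

In this assay, replacing propanoyl with isopropylcarbonyl gave a 1.4-fold higher number from compound 3 to compound 4 (0.14 log units; within the scatter), and this step does not differ measurably from the earlier one: the same change on two cores in this assay, a 2.4-fold higher number (0.38 log units; beyond the scatter) from compound 2 to compound 1 and a 1.4-fold higher number (0.14 log units; within the scatter) from compound 3 to compound 4, 1.7-fold (0.24 log units) apart, within the scatter of two such steps

So, on these two cores, the change carries over with no detectable difference in the size of its step. However, only the earlier step lies beyond the scatter, so the new pair alone would not establish an effect of the added methyl, and two pairs cannot show that the change would behave alike on other cores in the series.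

Still open, going by these compounds, is how the numbers would respond to a larger group at this carbonyl, such as tert-butylcarbonyl or cyclopropylcarbonyl. Also open, on these data alone, is whether the step would hold with an amide in place of the carboxylic acid.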